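This account rests on a few compounds, and the source may have more. Where it says the series, first, only, none or still open, it means among the compounds named here.

Measured compounds, all in a functional assay on HCT-116 cells (Homo sapiens) for inhibition; on this read-out higher numbers stand for weaker inhibition and lower numbers for stronger inhibition:
compound 1 `CCNC(=O)c1noc(-c2cc(C(C)C)c(O)cc2O)c1-c1cc(CO)no1` gives 13 nM
compound 2 `CCCNCc1cc(-c2c(C(=O)NCC)noc2-c2cc(C(C)C)c(O)cc2O)on1` gives 117 nM
compound 3 `CCNC(=O)c1noc(-c2cc(C(C)C)c(O)cc2O)c1-c1cc(C(N)=O)no1` gives 79 nM

Compound 1 holds the lowest number of the three. Both steps away from it lie beyond the scatter: a 6.1-fold higher number from compound 1 to compound 3 (0.78 log units; beyond the scatter) and a 9.0-fold higher number from compound 1 to compound 2 (0.95 log units; beyond the scatter). Between the other two the gap is small: a 1.5-fold lower number from compound 2 to compound 3 (0.17 log units; within the scatter).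

Compound 4 `CCNC(=O)c1noc(-c2cc(C(C)C)c(O)cc2O)c1-c1ccn(C)n1` differs from compound 1 as follows: 1-methyl-1H-pyrazol-3-yl in place of 3-(hydroxymethyl)-1,2-oxazol-5-yl on an aromatic carbon. Within the data shown here, no measured step swaps this whole ring, so the bearing is indirect. The two measured steps from compound 1 each alter the hydroxymethyl on that ring, and each raises the number by a modest amount; the change to compound 4 removes the hydroxymethyl together with its ring and brings in a ring carrying no hydrogen-bond donor. The expectation is therefore an upward step of roughly the size seen in those two, with wide uncertainty, since the replacement goes further than either. For compound 4 the estimate is 100 nM, with a range from 30 nM to 400 nM, which corresponds to an expected step of a 7.7-fold higher number from compound 1 to compound 4 (0.89 log units; beyond the scatter).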

Compound 4, half-maximal inhibitory concentration: 16 nM
Compound 4: middle estimate off by 6.3-fold (0.80 log units), on the high side; the measured number lies below the stated range.
By their numbers in this assay, from the lowest: compounds 1 and 4 (each within the scatter of the next); then compounds 3 and 2 (each within the scatter of the next).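

In this assay this position does not depend on the hydroxymethyl or on its 1,2-oxazole ring: 1-methyl-1H-pyrazol-3-yl in place of 3-(hydroxymethyl)-1,2-oxazol-5-yl gives a 1.2-fold higher number from compound 1 to compound 4 (0.09 log units; within the scatter), so for this pair the hydrogen-bond donor of the leaving group is not needed to hold the number. The same pyrazole also stands clear of the two other substituted rings, with a 4.9-fold lower number from compound 3 to compound 4 (0.69 log units; beyond the scatter) and a 7.3-fold lower number from compound 2 to compound 4 (0.86 log units; beyond the scatter), so the higher numbers of compound 3 and compound 2 go with carbamoyl and (propylamino)methyl on that ring rather than with the loss of hydroxymethyl alone. No measurement at hand gives a reason for any of these steps.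

The compounds shown leave open whether the methyl on the pyrazole nitrogen matters, since an ethyl or 2-hydroxyethyl group there, or a bare ring nitrogen-hydrogen, would test how much room this ring allows. They also leave open how a carboxylic acid or a primary amine on the 1,2-oxazole ring would compare with the carbamoyl of compound 3 and the (propylamino)methyl of compound 2.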